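Adding a 2-fluoro-5-methoxyphenyl group to compound 1

The compounds below may be only part of what the source reports. "The series", "measured", "known", "first", "only" and "open" are said of these compounds alone.

Measured compounds:
Compound 1, `Cc1ccccc1Cc1ccc(N2C[C@@H](C(F)(F)F)C[C@H]2CC(=O)O)cc1`, gives 67 nM in a functional assay on cells for agonist activity at Free fatty acid receptor 1 (Homo sapiens), read by FLIPR and calcium flux, with a stated time of 100 s; a higher number here means that more compound is needed for the effect, a lower number that less compound is needed.
Compound 2, `Cc1cccc(C)c1Oc1ccc(N2C[C@@H](C(F)(F)F)C[C@H]2CC(=O)O)cc1`, gives 82 nM in this assay.

Compound 1 has the lowest of the two numbers in this assay; its nearest neighbour is compound 2, and the step of a 1.2-fold higher number from compound 1 to compound 2 (0.09 log units; within the scatter) lies within the scatter, so the two cannot be ordered. Compound 3, `COc1ccc(F)c(-c2ccc(Cc3ccc(N4C[C@@H](C(F)(F)F)C[C@H]4CC(=O)O)cc3)c(C)c2)c1`, differs from compound 1 by 2-fluoro-5-methoxyphenyl in place of hydrogen on an aromatic carbon. Going by the values given here, the only measured step exchanges one aryl group for another on the shared core and does not add a group of this kind, so it bears on the new change only in showing that the outer aryl part tolerates variation without a step beyond the scatter. Among the compounds with values here, no measured pair shows what the addition of a second aromatic ring at this place does, so the direction of the step is uncertain. Compound 3 is therefore expected to remain close to compound 1, with a broad range, and the step of a 1.7-fold lower number from compound 1 to compound 3 (0.22 log units; within the scatter) is an estimate rather than an inference. The expected value for compound 3 in this assay is 40 nM, between 8 nM and 200 nM.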

Compound 3, half-maximal effective concentration: 490 nM
The estimate for compound 3 lay 12-fold (1.09 log units) below the measured number, outside the stated range (above it).
By their numbers in this assay, from the lowest: compounds 1 and 2 (each within the scatter of the next); then compound 3.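

In this assay, placing 2-fluoro-5-methoxyphenyl on the aromatic carbon that lies meta to a methyl group and para to a large group gives a 7.3-fold higher number from compound 1 to compound 3 (0.86 log units; beyond the scatter). Going by these compounds alone, this is the first step to lie beyond the scatter, so this position does not tolerate every change in the way the earlier exchange of 2-methylbenzyl for 2,6-dimethylphenoxy suggested, although the step is modest and compound 3 still gives a measurable 490 nM with the added six-membered aromatic ring in place. Nothing at hand explains the loss at this position, and the cost of the addition can be stated only as a number.

The compounds shown leave open whether the step follows from the added ring itself or from its fluorine and methoxy groups, since a plain phenyl ring at this place would be needed to separate the two. They also leave open how a much smaller group, such as a single fluorine, methoxy or hydroxyl, or a ring carrying an amine, would behave at this carbon.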